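A nitro group on the sulfonyl ring of compound 2

The source may report more compounds than this note shows. Statements on the series, on what has been measured and on what is new or still open speak of the compounds shown alone.

In an ADME assay on L02 cells (Homo sapiens) for cytotoxicity, read by MTT assay, with a stated time of 24 h (on this read-out lower numbers stand for stronger inhibition and higher numbers for weaker inhibition), compound 1 `O=C1/C(=C/c2ccncc2)CN(S(=O)(=O)c2ccc([N+](=O)[O-])cc2)C/C1=C\c1ccccc1F`, which carries (4-nitrophenyl)sulfonyl, gives 18400 nM. Compound 2 `O=C1/C(=C/c2ccncc2)CN(S(=O)(=O)c2ccccc2)C/C1=C\c1ccccc1C(F)(F)F`, with phenylsulfonyl, gives 12300 nM, which lies within the usual scatter of the value for compound 1. Compound 3 `O=C1/C(=C/c2ccncc2)CN(S(=O)(=O)c2ccc([N+](=O)[O-])cc2)C/C1=C\c1ccccc1C(F)(F)F` differs from compound 2 by nitro in place of hydrogen on an aromatic carbon, para to a large group: nitro in place of hydrogen on an aromatic carbon. The two measured compounds differ in more than one place, so neither value isolates this change. In this assay no shift beyond the scatter is expected, and the expected step is a 1.1-fold higher number from compound 2 to compound 3 (0.06 log units; within the scatter). The value of compound 3 is estimated at 14000 nM, with a range from 6000 nM to 32000 nM.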

Compound 3, half-maximal inhibitory concentration: 18600 nM
For compound 3 the middle estimate is 1.3-fold (0.12 log units) below the measured one; the measured number falls inside the stated range.
By their numbers in this assay, from the lowest: compounds 2, 1 and 3 (each within the scatter of the next).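

In this assay the step reads a 1.5-fold higher number from compound 2 to compound 3 (0.18 log units; within the scatter) for nitro in place of hydrogen on an aromatic carbon, para to a large group, and a 1.0-fold higher number from compound 1 to compound 3 (0.00 log units; within the scatter) for trifluoromethyl in place of fluoro on an aromatic carbon. Among these compounds, these are the first readings of either exchange on its own, and neither moves the number beyond the scatter. Nothing available explains this result. Going by these compounds, what an amine or a carboxylic acid would do at the nitro position remains open, as does the outcome with a chloro group in place of the trifluoromethyl.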